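Alkyne aryl variants: from compound 3 to compound 4

The compounds below may be only part of what the source reports. "The series", "measured", "known", "first", "only" and "open" are said of these compounds alone.

Compound 1 `C[C@@H](NC(=O)c1ccc(C#Cc2ccccc2F)cn1)C(C)(C)O` gives 60% in a functional assay on HEK293 cells for positive allosteric modulation of metabotropic glutamate receptor 5 (Rattus norvegicus), read by fluorescence and calcium flux; a lower number here means a smaller maximal response, a higher number a larger maximal response. Compound 2 `C[C@@H](NC(=O)c1ccc(C#Cc2ccc(F)cc2)cn1)C(C)(C)O` gives 66.2%, and compound 3 `Cc1cccc(C#Cc2ccc(C(=O)N[C@H](C)C(C)(C)O)nc2)c1` gives 68.6%. Compound 3 holds the highest of the three numbers, yet all three lie within the scatter of one another: a number 6.2 percentage points higher from compound 1 to compound 2 (within the scatter), a number 8.6 percentage points higher from compound 1 to compound 3 (within the scatter) and a number 2.4 percentage points higher from compound 2 to compound 3 (within the scatter). Compound 4 `Cc1ccc(C#Cc2ccc(C(=O)N[C@H](C)C(C)(C)O)nc2)cc1` differs from compound 3 by 4-methylphenyl in place of 3-methylphenyl on a triple-bonded carbon. Going by the values given here, every measured step so far exchanges one aryl group on the triple-bonded carbon for another, and none moved the maximal response beyond the scatter, whether a fluorophenyl or a methylphenyl entered. For compound 4 the maximal response is therefore expected to stay close, the expected step being a number 0.6 percentage points lower from compound 3 to compound 4 (within the scatter), none beyond the scatter. The estimate for compound 4 is 68%, within 58% to 78%.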

Compound 4, largest response reached (reported as efficacy), in percent of the reference or control that the assay uses: 63.1%
Beside the measured number, compound 4's estimate is 4.9 percentage points above it; the measured number falls inside the stated range.
By their numbers in this assay, from the lowest: compounds 1, 4, 2 and 3 (each within the scatter of the next).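

Within the methylphenyl pair, a number 5.5 percentage points lower from compound 3 to compound 4 (within the scatter) in this assay shows that 4-methylphenyl in place of 3-methylphenyl on a triple-bonded carbon leaves the maximal response unresolved from the earlier values. With a number 3.1 percentage points lower from compound 2 to compound 4 (within the scatter) for methyl in place of fluoro and a number 3.1 percentage points higher from compound 1 to compound 4 (within the scatter) across both substituent and ring position, all four compounds remain within the scatter of one another. No supporting data bear on these small steps.

Going by these compounds, whether a carboxylic acid or an amine on the phenyl ring would move the maximal response beyond the scatter stays open.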